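Removing the cyclopentyl from the aromatic nitrogen of compound 1

The compounds below may be only part of what the source reports. "The series", "measured", "known", "first", "only" and "open" are said of these compounds alone.

Compound 1, `COc1cc(C(=O)O)ccc1Cc1cn(C2CCCC2)c2ccc(NC(=O)OC3CCCC3)cc12`, is an indole-type acid, and in an assay on isolated protein (Cavia porcellus) with cysteinyl leukotriene receptor (Homo sapiens) as the target (on this read-out lower numbers stand for lower potency and higher numbers for higher potency (the scale is a negative logarithm)), compound 1 gives 7.67, the lowest of the three numbers recorded. Compound 2, `COc1cc(C(=O)NS(=O)(=O)c2ccccc2)ccc1Cc1cn(C2CCCC2)c2ccc(NC(=O)OC3CCCC3)cc12`, replaces the acid with a sulfonamide and gives 7.84, a change described as a number 0.17 log units higher from compound 1 to compound 2 (within the scatter). Compound 3, `COc1cc(C(=O)NS(=O)(=O)c2ccccc2C)ccc1Cc1cn(C)c2ccc(NC(=O)NC3CCCC3)cc12`, differs from compound 1 in several places at once; compound 3 gives 9.31. Its gap to compound 1 lies beyond the scatter, but it cannot be tied to any one of those changes.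

Compound 4, `COc1cc(C(=O)O)ccc1Cc1c[nH]c2ccc(NC(=O)OC3CCCC3)cc12`, is obtained from compound 1 by the change (hydrogen in place of cyclopentyl on an aromatic nitrogen). Among the measured compounds shown here, no measured pair tests this change on its own: compound 3 carries a methyl on that nitrogen, yet its other alterations block any reading. With no direct guide, a moderate fall is expected, the step from compound 1 to compound 4 estimated as a number 0.47 log units lower from compound 1 to compound 4 (beyond the scatter), so compound 4 is expected near 7.2, within 6.4 to 8.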

Compound 4, negative logarithm of the antagonist equilibrium constant: 7.32
The estimate for compound 4 lay 0.12 log units below the measured number; measured number inside the range.
By their numbers in this assay, from the lowest: compound 4; then compounds 1 and 2 (each within the scatter of the next); then compound 3.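

In this assay, among the compounds shown here, this is the first clean test of the group on the aromatic nitrogen: with everything else in compound 1 kept, hydrogen in place of cyclopentyl gives a number 0.35 log units lower from compound 1 to compound 4 (beyond the scatter) as a modest step. The number does respond to this position, but losing the whole five-carbon ring costs only a limited amount, so binding in this assay does not depend on the cyclopentyl being present. The data offer no measured property that accounts for the fall.

Still open is how the number would respond to an ethyl, a benzyl or a longer alkyl chain on this nitrogen, since the compounds shown give only cyclopentyl and hydrogen on an otherwise unchanged acid. On these data alone, it is also open whether the same step would appear in compound 2, where the acid is replaced.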